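Tetrazole in Place of Carboxy on Two Different Cores

The compounds below may be only part of what the source reports. "The series", "measured", "known", "first", "only" and "open" are said of these compounds alone.

Compound 1 `c1ccc2nc(COc3ccc(OCCCc4nnn[nH]4)cc3)ccc2c1`: 69 nM
Compound 2 `O=C(O)CCCOc1ccc(OCc2ccc3ccccc3n2)cc1`: 1200 nM
Compound 3 `O=C(O)CC1(CCc2ccc(OCc3ccc4ccccc4n3)cc2)CCCC1`: 51 nM

Of the compounds shown here, three have been tested in an assay on membranes from lung (Cavia porcellus) for binding affinity to cysteinyl leukotriene receptor (Homo sapiens); on this read-out higher numbers stand for weaker inhibition and lower numbers for stronger inhibition. Compound 2 gives 1200 nM, compound 1 gives 69 nM, and compound 3 gives 51 nM. Compounds 1 and 3 lie within the usual scatter of each other, so neither can be called the stronger of the two.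

Compounds 2 and 1 differ in one place: 1H-tetrazol-5-yl in place of carboxy on a saturated chain carbon, three bonds along the chain from an oxygen on an aromatic ring. This single change made a large step, a 17-fold lower number from compound 2 to compound 1 (1.24 log units; beyond the scatter).

Compound 3 carries its carboxy group on a different core; the difference between the two cores is not broken down here. Compound 4 `c1ccc2nc(COc3ccc(CCC4(Cc5nnn[nH]5)CCCC4)cc3)ccc2c1` has not yet been measured in this assay. It is related to compound 3 by the same kind of change: 1H-tetrazol-5-yl in place of carboxy on a saturated chain carbon bound to a saturated ring carbon. The place is not the same word for word: in compound 2 the carboxy sits on a saturated chain carbon three bonds along the chain from an oxygen on an aromatic ring, whereas in compound 3 it sits on a saturated chain carbon bound to a saturated ring carbon.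

Because the earlier exchange gave a 17-fold lower number from compound 2 to compound 1 (1.24 log units; beyond the scatter), compound 4 is expected to show a lower number than compound 3, with a step estimated at a 5.1-fold lower number from compound 3 to compound 4 (0.71 log units; beyond the scatter), though smaller than before, since compound 3 already sits at the low end of the measured range and the surroundings of the change differ. The estimate for compound 4 in this assay is 10 nM, most likely between 2 nM and 40 nM.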

Compound 4, inhibition constant: 25 nM
Beside the measured number, compound 4's estimate is 2.5-fold (0.40 log units) below it; measured number inside the range.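

On the second core, 1H-tetrazol-5-yl in place of carboxy again lowers the number in this assay, giving a 2.0-fold lower number from compound 3 to compound 4 (0.31 log units; beyond the scatter) as the result, so the direction of the change holds in both pairs shown. The size of the step does not carry over, and a large gain on one core gives no assurance of an equally large gain on another: the same change on two cores in this assay, a 17-fold lower number (1.24 log units; beyond the scatter) from compound 2 to compound 1 and a 2.0-fold lower number (0.31 log units; beyond the scatter) from compound 3 to compound 4, 8.5-fold (0.93 log units) apart, beyond the scatter of two such steps

Going by these compounds alone, with only two pairs, these numbers do not show which part of the cores sets the size of the step, and they give no basis for predicting the step on a third core.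

The compounds shown leave open whether another group in the same place, such as an amide or a sulfonamide, would lower the number as 1H-tetrazol-5-yl does. They also leave open whether a longer chain carrying the 1H-tetrazol-5-yl group would bring the size of the step on the two cores closer together or push it further apart.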